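The source may hold more compounds than are shown below. What is called first, only, known or untested is meant among the compounds shown, and "the series" means these compounds.

Measured so far in a functional assay on MCF7 cells (Homo sapiens) for cytotoxicity, read by MTT assay, with a stated time of 48 h; a lower number here means a stronger inhibitor, a higher number a weaker inhibitor:
compound 1 `C=CC(=C)CC[C@@H]1[C@@]2(C)CCC[C@](C)(COC(=O)/C=C\c3ccc(O)cc3)[C@@H]2CC[C@@]1(C)O` gives 15100 nM.
Compound 2 `C=CC(=C)[C@@H](O)C[C@H]1C(=C)CC[C@@H]2[C@]1(C)CCC[C@]2(C)C(=O)O` gives only a limit, > 40000 nM.
Compound 3 `C=C1CC[C@@H]2[C@](C)(CCC[C@]2(C)C(=O)O)[C@H]1C/C=C(\C)C=O` gives only a limit, > 40000 nM.

Compound 3 stands at the limit shared by two of the three values shown (the limit of > 40000 nM in this assay, at which 2 of the 3 values shown sit). Compound 1 alone gives a number in this assay. Among the compounds with values here, the one step between measured compounds, a step that the two limits leave unreadable from compound 2 to compound 3, is unreadable, both values being limits. Compound 4 `C=C[C@]1(C)O[C@H]1C[C@H]1C(=C)CC[C@@H]2[C@]1(C)CCC[C@]2(C)C(=O)O` differs from compound 3 by a group of 6 heavy atoms (5 carbon, 1 oxygen; one three-membered non-aromatic ring with 1 hetero atom) in place of a group of 5 heavy atoms (4 carbon, 1 oxygen; no ring), on a saturated chain carbon bound to a saturated ring carbon. Within the data shown here, no measured step bears on this change. Compound 3 sits at its limit > 40000 nM. Compound 4 is expected to stay near that limit, a step that the limit leaves unreadable from compound 3 to compound 4 in this assay. Compound 4 is therefore estimated at 45000 nM, within 15000 nM to 150000 nM, most likely again reported only as a limit.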

Compound 4, half-maximal inhibitory concentration: > 40000 nM
Compound 4: only a limit was reported; the forecaster's own chance of this, stated with the estimate: 65%; the middle value does not contradict the limit.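

Compound 4 gives only a limit, as do compound 2 and compound 3, so no new step can be read among these three: the limit of > 40000 nM in this assay, at which 3 of the 4 values shown sit. The compounds shown leave open how the three side chains on the shared core rank against one another.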